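The compounds below may be only part of what the source reports. "The series", "measured", "known", "first", "only" and "open" are said of these compounds alone.

Compound 1 `CC(C)(C)c1ccc(NC(=O)c2ccc(-c3ccccn3)cc2)cc1` is the parent of this small set. In a functional assay for antagonist activity at transient receptor potential cation channel subfamily V member 1 (Rattus norvegicus) (on this read-out higher numbers stand for weaker inhibition and lower numbers for stronger inhibition), compound 1 gives 8 nM. Compound 2 `CCCOc1cccnc1-c1ccc(C(=O)Nc2ccc(C(C)(C)C)cc2)cc1` carries a propoxy group on an aromatic carbon of the shared core, and in this assay compound 2 gives 20 nM. Compound 3 `CCCNc1cccnc1-c1ccc(C(=O)Nc2ccc(C(C)(C)C)cc2)cc1` carries a propylamino group at that same place, and in this assay compound 3 gives 37 nM. Compound 3 thus holds the highest number of the three, which on this read-out means the weakest inhibition; its nearest neighbour is compound 2, within the scatter, while the gap to compound 1 lies beyond it. The steps show this directly: a 2.5-fold higher number from compound 1 to compound 2 (0.40 log units; beyond the scatter) and a 4.6-fold higher number from compound 1 to compound 3 (0.67 log units; beyond the scatter), whereas a 1.9-fold higher number from compound 2 to compound 3 (0.27 log units; within the scatter).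

Compound 4 `CC(C)(C)c1ccc(NC(=O)c2ccc(-c3ncccc3N(S(C)(=O)=O)S(C)(=O)=O)cc2)cc1` differs from compound 3 in one place: bis(methylsulfonyl)amino in place of propylamino on an aromatic carbon. For the measured compounds named here, no measured step involves this entering group, so guidance is only indirect. Both substitutions made at this place, starting from hydrogen, raised the number modestly, and the entering group brings more heavy atoms and no hydrogen-bond donor, as the count shows. The expectation is therefore a further rise, of uncertain size. For compound 4 the estimate in this assay is 120 nM, with a range from 35 nM to 450 nM. This expected step, a 3.2-fold higher number from compound 3 to compound 4 (0.51 log units; beyond the scatter), would be estimated to lie beyond the scatter.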

Compound 4, half-maximal inhibitory concentration: 0.4 nM
Compound 4: middle estimate off by 300-fold (2.48 log units), on the high side; measured number below the stated range.
By their numbers in this assay, from the lowest: compound 4; then compound 1; then compounds 2 and 3 (each within the scatter of the next).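

In this assay the change from hydrogen to bis(methylsulfonyl)amino gives a 20-fold lower number from compound 1 to compound 4 (1.30 log units; beyond the scatter) and so runs opposite to the propoxy and propylamino groups, which both raised the number from that of compound 1. This place on the aromatic ring, ortho to a large group and two atoms from the ring nitrogen, therefore does more than tolerate or mildly penalise a substituent: what sits there can strengthen inhibition well past that of the unsubstituted parent, and the choice of group matters greatly, as a 50-fold lower number from compound 2 to compound 4 (1.70 log units; beyond the scatter) and a 93-fold lower number from compound 3 to compound 4 (1.97 log units; beyond the scatter) both show. The entering group differs from propylamino in several counted ways at once, including more heavy atoms, more hydrogen-bond acceptors and no hydrogen-bond donor, and no independent measurement shows which of these differences, if any, accounts for the result.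

As far as these compounds go, it remains open whether both methylsulfonyl groups are needed, since a single methylsulfonylamino group, which keeps one nitrogen-bound hydrogen, would separate the effect of one sulfonyl unit from that of two. An acetylamino group or a larger bis(ethylsulfonyl)amino group would likewise show how closely the gain is tied to this exact group.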